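Two Chlorines Enter the Benzyl Ring of Compound 3

The source may hold more compounds than are shown below. What is called first, only, known or untested is meant among the compounds shown, and "the series" means these compounds.

Compound 3 `O=S(=O)(NCCCNCc1ccccc1)c1cc(C(F)(F)F)cc(C(F)(F)F)c1` shows the highest number of the three measured compounds in a functional assay on BE(2)-C cells (Homo sapiens) for inhibition, read by MTT assay, with a stated time of 72 h (a higher number here means a weaker inhibitor of growth, a lower number a stronger inhibitor of growth), giving 12000 nM; compound 1 `O=S(=O)(NCCCNCc1ccc(Cl)c(C(F)(F)F)c1)c1cc(C(F)(F)F)cc(C(F)(F)F)c1` gives 8600 nM and compound 2 `COc1ccccc1CNCCCNS(=O)(=O)c1cc(C(F)(F)F)cc(C(F)(F)F)c1` gives 3600 nM. Compound 4 `O=S(=O)(NCCCNCc1ccc(Cl)c(Cl)c1)c1cc(C(F)(F)F)cc(C(F)(F)F)c1` differs from compound 3 by 3,4-dichlorophenyl in place of phenyl on a saturated chain carbon bound to an amine nitrogen. The closest comparison is a 1.4-fold higher number from compound 1 to compound 3 (0.14 log units; within the scatter), a change within the scatter, so substituents on this ring have so far changed little. The other step, a 3.3-fold higher number from compound 2 to compound 3 (0.52 log units; beyond the scatter), concerns a different substituent and bears only loosely on this case. A small lowering is therefore expected for compound 4, roughly a 1.6-fold lower number from compound 3 to compound 4 (0.20 log units; within the scatter), which may not stand clear of the scatter. Compound 4 is estimated at 7500 nM, with a range from 3000 nM to 18000 nM.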

Compound 4, concentration for 50% growth inhibition: 2900 nM
Compound 4: the middle estimate sits 2.6-fold (0.41 log units) above what was measured, outside the stated range (below it).
By their numbers in this assay, from the lowest: compounds 4 and 2 (each within the scatter of the next); then compounds 1 and 3 (each within the scatter of the next).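

In this assay a ring substituent now moves the number clearly, with a 4.1-fold lower number from compound 3 to compound 4 (0.62 log units; beyond the scatter) as the 3,4-dichlorophenyl ring replaces phenyl, which the earlier change to 4-chloro-3-(trifluoromethyl)phenyl did not do. The swap of one group on this ring also counts, with a 3.0-fold lower number from compound 1 to compound 4 (0.47 log units; beyond the scatter) as chloro replaces trifluoromethyl. Two different rings reach the same range, with a 1.2-fold lower number from compound 2 to compound 4 (0.09 log units; within the scatter) leaving no real gap.

Nothing measured here explains these differences. From the compounds shown here alone, whether a nitrile or a carboxylic acid on this ring, or a longer chain in the linker, would change the number remains open.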